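From Ethoxycarbonyl to Isobutoxycarbonyl on a Shared Core

The source may hold more compounds than are shown below. What is called first, only, known or untested is meant among the compounds shown, and "the series" means these compounds.

Compound 1 `COC(=O)N1CCC(Oc2ncnc(Oc3ccc(/C=C4\SC(=O)NC4=O)cc3)c2C)CC1` and compound 2 `CCOC(=O)N1CCC(Oc2ncnc(Oc3ccc(/C=C4\SC(=O)NC4=O)cc3)c2C)CC1` share one core and differ only in the chain on the oxygen next to the carbonyl group. In a functional assay on CHO-K1 cells for agonist activity at Glucose-dependent insulinotropic receptor (Homo sapiens), read by cAMP accumulation and immunoassay, with a stated time of 1 h (on this read-out higher numbers stand for larger maximal responses and lower numbers for smaller maximal responses), compound 1 gives 53.3%, while compound 2 gives 141%, the higher of the two numbers. For the measured compounds named here, the single measured step, a number 87.7 percentage points higher from compound 1 to compound 2 (beyond the scatter), was large. Compound 3 `Cc1c(Oc2ccc(/C=C3\SC(=O)NC3=O)cc2)ncnc1OC1CCN(C(=O)OCC(C)C)CC1` carries the change (isopropyl in place of methyl on a saturated chain carbon bound to an oxygen next to a carbonyl group). Going by the values given here, only that one step bears on it, and a further gain or a plateau are both plausible. The step expected is a number 1 percentage points lower from compound 2 to compound 3 (within the scatter). Compound 3 is therefore expected to reach 140%, within 90% to 190%.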

Compound 3, largest response reached (Emax), in percent of the reference or control that the assay uses: 70.2%
The estimate for compound 3 lay 69.8 percentage points above the measured number, outside the stated range (below it).
By their numbers in this assay, from the lowest: compound 1; then compound 3; then compound 2.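

Lengthening the chain beyond ethyl does not keep raising the response: in this assay, going from ethoxycarbonyl to isobutoxycarbonyl gives a number 70.8 percentage points lower from compound 2 to compound 3 (beyond the scatter). The isobutyl chain still keeps some gain over the methyl chain, with a number 16.9 percentage points higher from compound 1 to compound 3 (beyond the scatter), so among these three compounds the response rises and then falls, with ethyl giving the highest number. Nothing measured here explains this fall. Still open, as far as these compounds go, is whether chain length or branching matters more, which a straight propyl or butyl chain at the same place could help separate.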